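Chlorophenyl-to-phenyl step in a fused dimedone series

A few compounds are considered here, and "the series" means these few. Any claim that something is new, unique, unknown or untested is made for them only; others in the source may bear on it.

Measured compounds:
- compound 1 `CCOC(=O)C1=CC(c2ccc(Br)cc2)C2=C(CC(C)(C)CC2=O)N1`: "not active" (no number reported)
- compound 2 `CCOC(=O)C1(O)CC(c2ccc(Cl)cc2)C2=C(CC(C)(C)CC2=O)O1`: "not active" (no number reported)
- compound 3 `CC1(C)CC(=O)c2c(-c3ccc(F)cc3)cc(-c3ccccc3)nc2C1`: 11.1%

In an assay on isolated protein for inhibition of glucose-6-phosphatase catalytic subunit 1 (Homo sapiens), read by inositol phosphate accumulation, with a stated time of 30 min, tested at 100 uM (a higher number here means more inhibition at the concentration tested (going by the name of the read-out), a lower number less inhibition), compound 3 gives 11.1%. In this assay compound 1 gives "not active" (no number reported), and compound 2 likewise gives "not active" (no number reported), so compound 2 stands without a single number, as does one further entry in the set. Among the measured compounds shown here, no step between measured compounds is available for this change.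

Compound 4 `CCOC(=O)C1(O)CC(c2ccccc2)C2=C(CC(C)(C)CC2=O)O1` differs from compound 2 by hydrogen in place of chloro on an aromatic carbon, that is, 4-chlorophenyl to phenyl. With compound 2 reporting no number, the step is expected to stay within the scatter, with no direction beyond it.

For compound 4 in this assay the estimate is 5%, within -10% to 20%, and a report of no number is thought more likely than a value.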

Compound 4, a percentage reported as inhibition, at one concentration (the size of the read-out at that concentration, not a potency): "not active" (no number reported)
The entry for compound 4 holds no number; the estimate stays without a comparison.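

In this assay compound 2 gives "not active" (no number reported) and compound 4 gives "not active" (no number reported) so no step can be read between them. The compounds shown leave open whether 4-chlorophenyl to phenyl changes inhibition at all. No supporting evidence bears on this result.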